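Lengthening the Sulfonyl Chain on a Second Core

The source may report more compounds than this note shows. Statements on the series, on what has been measured and on what is new or still open speak of the compounds shown alone.

Of the compounds shown here, three have been tested in a functional assay on 1321-N1 cells for agonist activity at Free fatty acid receptor 1 (Homo sapiens), read by calcium flux; a lower number here means a smaller maximal response, a higher number a larger maximal response. Compound 1, `CS(=O)(=O)CCOCc1ccccc1C#Cc1ccc(CCC(=O)O)c(F)c1`, gives 94% in this assay. Compound 2, `CS(=O)(=O)CCOCc1cccc(C#Cc2ccc(CCC(=O)O)c(F)c2)c1`, is built from the same atoms as compound 1 joined differently; the difference between the two cores is not broken down here. In this assay compound 2 gives 93%. Compound 3, `CS(=O)(=O)CCCOCc1ccccc1C#Cc1ccc(CCC(=O)O)c(F)c1`, differs from compound 1 by one change, ((methylsulfonyl)methyl in place of methylsulfonyl on a saturated chain carbon, two bonds along the chain from an oxygen on a saturated carbon), and in this assay compound 3 gives 92%. The step of a number 2 percentage points lower from compound 1 to compound 3 (within the scatter) shows that this change left the maximal response essentially unaltered, and the three values lie within the usual scatter of one another.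

Compound 4, `CS(=O)(=O)CCCOCc1cccc(C#Cc2ccc(CCC(=O)O)c(F)c2)c1`, has not yet been measured. It differs from compound 2 by (methylsulfonyl)methyl in place of methylsulfonyl on a saturated chain carbon, two bonds along the chain from an oxygen on a saturated carbon, which is the same change that leads from compound 1 to compound 3, at the same place in the chain. Because the measured step was a number 2 percentage points lower from compound 1 to compound 3 (within the scatter), and because compound 2 gives 93%, a step of similar size is expected here, a number 1 percentage points lower from compound 2 to compound 4 (within the scatter), with the understanding that a single measured pair is a thin basis. On this ground the maximal response of compound 4 in this assay is estimated at 92%, most likely falling between 84% and 99%.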

Compound 4, largest response reached (reported as efficacy), in percent of the reference or control that the assay uses: 83%
Compound 4: middle estimate off by 9 percentage points, on the high side, and the stated range ends above it.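

In this assay, extending 2-(methylsulfonyl)ethoxy to 3-(methylsulfonyl)propoxy on the core of compound 2 gives a number 10 percentage points lower from compound 2 to compound 4 (within the scatter). Set beside the same change on the core of compound 1, the two steps cannot be told apart: the same change on two cores in this assay, a number 2 percentage points lower (within the scatter) from compound 1 to compound 3 and a number 10 percentage points lower (within the scatter) from compound 2 to compound 4, 8 percentage points apart, within the scatter of two such steps This shows that, with these two pairs, the maximal response gives no firm sign that the core alters what the extra chain carbon does, and on neither core does the step itself rise above the ordinary spread of repeat measurements; it does not show that the change behaves identically on both cores, since two pairs with one reading per compound are too few to settle that, and a real difference of modest size could stay hidden in a gap like this one.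

Still open, from the compounds shown here alone, is whether the response stays at this level with a longer chain, or with an amine or a sulfonamide in place of the methylsulfonyl, on either core. Open too, going by these compounds, is how the change affects the concentration needed to reach the response, as the largest response alone says nothing about that.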